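Aryloxypropoxy spirocycle: swapping ring substituents

This account rests on a few compounds, and the source may have more. Where it says the series, first, only, none or still open, it means among the compounds named here.

Compounds measured so far:
compound 1 `NC1=NC2(CCOCC2)N(OCCCOc2ccccc2)C(N)=N1` — "not determined" (no result reported) in a functional assay on HepG2 cells (Homo sapiens) for antiproliferative activity, read by MTT assay, with a stated time of 72 h; a lower number here means a stronger inhibitor, a higher number a weaker inhibitor
compound 2 `NC1=NC2(CCOCC2)N(OCCCOc2cccc(Cl)c2Cl)C(N)=N1` — 330 nM

Compound 2 stands alone with a number in this assay; compound 1 carries none. The next compound, compound 3 `Cc1cc(C)cc(OCCCON2C(N)=NC(N)=NC23CCOCC3)c1`, differs from compound 2 by 3,5-dimethylphenyl in place of 2,3-dichlorophenyl on an oxygen on a saturated carbon. For the measured compounds named here, no step between two measured compounds is available, so the size of this change is unknown from the data. It is expected that the step of a 1.5-fold higher number from compound 2 to compound 3 (0.18 log units; within the scatter) stays within the usual scatter, in either direction. Compound 3 is therefore estimated at 500 nM, in a range from 150 nM to 1600 nM.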

Compound 3, half-maximal inhibitory concentration: 680 nM
Compound 3: middle estimate off by 1.4-fold (0.13 log units), on the low side; the range from low to high includes it.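

In this assay, 3,5-dimethylphenyl in place of 2,3-dichlorophenyl on an oxygen on a saturated carbon gives a 2.1-fold higher number from compound 2 to compound 3 (0.31 log units; beyond the scatter), the first measured size for a change at this position. The step is modest, and activity is retained after both chlorines give way to methyl groups. Nothing available explains the shift. Since the two groups differ in both substituent and placement, the compounds shown do not separate these two factors. Also open, from the compounds shown here alone, is how a phenyl ring carrying an amine or a carboxylic acid would compare.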